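The source may report more compounds than this note shows. Statements on the series, on what has been measured and on what is new or still open speak of the compounds shown alone.

Compound 1 `CCCCC[Se]c1nc(NCc2ccc(SC)cc2)c2ccccc2n1` carries a pentylselanyl group on the shared core. In a functional assay on HT-29 cells (Homo sapiens) for cytotoxicity, read by MTT assay, with a stated time of 72 h (a lower number here means that less compound is tolerated, a higher number that more compound is tolerated), compound 1 gives > 100000 nM, which is a limit of the assay rather than a number. Compound 2 `CCCCC[Se]c1nc(NCc2ccccc2)c2ccccc2n1` likewise gives > 100000 nM, again a limit. Compound 3 `CSc1nc(NCc2ccc([Se]C)cc2)c2ccccc2n1` gives > 100000 nM, also a limit. Among the measured compounds shown here, the only measured step, a step that the two limits leave unreadable from compound 1 to compound 2, thus offers no readable size or direction. Compound 4 `CSc1ccc(CNc2nc([Se]C)nc3ccccc23)cc1` differs from compound 1 in hydrogen in place of butyl on a saturated chain carbon bound to a selenium atom. Because the limit of > 100000 nM in this assay, at which 3 of the 3 values shown sit, holds for every value shown, nothing measured points to a change in either direction for this shortening, and compound 4 is expected to sit at the same limit. Compound 4 is therefore estimated at 150000 nM, between 50000 nM and 500000 nM, a step that the limit leaves unreadable from compound 1 to compound 4 expected to be none beyond the scatter.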

Compound 4, concentration lethal to 50% of the cells: > 100000 nM
Compound 4: a limit, no number (the forecaster's own chance of this, stated with the estimate: 85%); the middle value does not contradict the limit.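

In this assay compound 4 gives > 100000 nM, again a limit. The step between compound 1 and compound 4 therefore cannot be read. The compounds shown leave open whether pentyl and methyl differ at all in their effect on these cells.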